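The source may report more compounds than this note shows. Statements on the series, on what has been measured and on what is new or still open speak of the compounds shown alone.

Measured compounds in an assay on COS-7 cells for inhibition of diacylglycerol lipase-alpha (Homo sapiens), read by scintillation counting; on this read-out higher numbers stand for weaker inhibition and lower numbers for stronger inhibition:
Compound 1 `CCCCCCCCCCC[C@@H](C[C@@H]1OC(=O)[C@H]1CCCCCC)OC(=O)[C@H](CC(C)C)NC(=O)OC(C)(C)C` gives > 25000 nM, which is a limit of the assay.
Compound 2 `CCCCCCCCCCC[C@@H](C[C@@H]1OC(=O)[C@H]1CCCCCC)OC(=O)[C@@H](N)CC(C)C` gives > 25000 nM, which is a limit of the assay.
Compound 3 `CCCCCCCCCCC[C@@H](C[C@@H]1OC(=O)[C@H]1CCCCCC)OC(=O)[C@H](C)NC=O` gives 43 nM.

Compound 3 is the only one of the three that yields an actual number in this assay; the other two sit at a limit of the assay (the limit of > 25000 nM in this assay, at which 2 of the 3 values shown sit). The step from compound 1 to compound 2 is a step that the two limits leave unreadable from compound 1 to compound 2. The step from compound 2 to compound 3 is an at least 580-fold lower number from compound 2 to compound 3 (2.76 log units; beyond the scatter), which shows that the group on the carbonyl carbon next to the ester oxygen governs the read-out strongly.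

Compound 4 `CCCCCCCCCCC[C@@H](C[C@@H]1OC(=O)[C@H]1CCCCCC)OC(=O)[C@@H]1CCC(=O)N1` differs from compound 3 in that (a group of 6 heavy atoms (4 carbon, 1 nitrogen, 1 oxygen; one five-membered non-aromatic ring with 1 hetero atom) in place of a group of 5 heavy atoms (3 carbon, 1 nitrogen, 1 oxygen; no ring), on a carbonyl carbon). Among the measured compounds shown here, the change keeps one hydrogen-bond donor and one hydrogen-bond acceptor in this part of the molecule and keeps a defined stereocentre, so the step that bears on it most is the one from compound 2 to compound 3, in which introducing a formyl-bearing group with the same donor and acceptor count brought the number down sharply. For the measured compounds named here, no measured pair shows what closing this group into a ring does. Compound 4 is therefore estimated to remain close to compound 3, with an expected step of a 2.3-fold higher number from compound 3 to compound 4 (0.37 log units; beyond the scatter), and an estimated value of 100 nM, in the range 20 nM to 1000 nM.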

Compound 4, half-maximal inhibitory concentration: 100 nM
Estimate against measurement, compound 4: no gap at the digits printed; low and high end bracket the measured number.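

In this assay, the result shows that a group closed into a ring, 5-oxopyrrolidin-2-yl, can stand on this carbonyl carbon and still give a number in the same low range as the open group of compound 3, with a modest step that lies beyond the scatter: a 2.3-fold higher number from compound 3 to compound 4 (0.37 log units; beyond the scatter). Before this, only one group at this place had given a readable number, and now a second one stands far from the 1-amino-3-methylbutyl group, with a large step: an at least 250-fold lower number from compound 2 to compound 4 (2.39 log units; beyond the scatter). As far as these compounds go, the value of compound 2 behind that step is a limit and not a number, so the true size of the step stays unknown: the limit of > 25000 nM in this assay, at which 2 of the 4 values shown sit.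

Compound 3 and compound 4 differ in the whole group, so the compounds shown do not separate the effect of closing the ring from that of the other changes within it. From the compounds shown here alone, it remains open what a six-membered ring carrying the same carbonyl, or a carboxylic acid on the five-membered ring, would give on this carbonyl carbon, and what the opposite configuration at the defined stereocentre of 5-oxopyrrolidin-2-yl would give.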